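The source may hold more compounds than are shown below. What is called first, only, known or untested is meant among the compounds shown, and "the series" means these compounds.

Measured in a functional assay on HCT-116 cells (Homo sapiens) for antiproliferative activity, read by sulforhodamine B assay, with a stated time of 48 h; on this read-out higher numbers stand for weaker inhibition of growth and lower numbers for stronger inhibition of growth:
- compound 1 `O=C(/C=C/c1ccc2cc(C(=O)c3ccc(F)cc3)ccc2n1)NO`: 1840 nM
- compound 2 `COc1ccc(C(=O)c2ccc3nc(/C=C/C(=O)NO)ccc3c2)cc1`: 2300 nM

Compound 2, at 2300 nM, stands level with compound 1 within the scatter. Within the data shown here, the one measured step between them is a 1.3-fold higher number from compound 1 to compound 2 (0.10 log units; within the scatter), with methoxy in place of fluoro on an aromatic carbon.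

Compound 3 `COc1ccc(C(=O)c2ccc3nc(/C=C/C(=O)NO)ccc3c2)cc1OC` has not yet been measured. It departs from compound 2 by methoxy in place of hydrogen on an aromatic carbon, ortho to a methoxy group. Among the measured compounds shown here, no measured step makes this same change, so the step to compound 1 offers only indirect guidance: a swap of one group on an aromatic carbon gave a 1.3-fold higher number from compound 1 to compound 2 (0.10 log units; within the scatter). On that slender basis, no change beyond the scatter is expected in this assay. The expected step is a 1.2-fold lower number from compound 2 to compound 3 (0.06 log units; within the scatter). For compound 3 the estimate is 2000 nM, with an expected range of 900 nM to 4500 nM.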

Compound 3, concentration for 50% growth inhibition: 1780 nM
Beside the measured number, compound 3's estimate is 1.1-fold (0.05 log units) above it, within the range that was stated.
By their numbers in this assay, from the lowest: compounds 3, 1 and 2 (each within the scatter of the next).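

In this assay, methoxy entering in place of hydrogen, ortho to a methoxy group and meta to a large group, gives a 1.3-fold lower number from compound 2 to compound 3 (0.11 log units; within the scatter) and so leaves the number level within the scatter. Compound 1 and compound 2 had shown only one group swapped for another on this ring, whereas this change adds a group at a carbon that carried hydrogen, and the ring accepts this second methoxy without a change that can be told from the scatter. Nothing available here explains this outcome.

Going by these compounds, whether this carbon accepts groups other than methoxy remains open, since an amine, a carboxylic acid or a longer chain such as ethoxy could give a different number. The compounds shown also leave open whether the other carbons of this ring would behave in the same way.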